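Changing the aryl group of compound 1

The compounds below may be only part of what the source reports. "The series", "measured", "known", "first", "only" and "open" are said of these compounds alone.

In an ADME assay (liver) for metabolic stability, with Liver microsome (Homo sapiens) as the target, read by LC-MS, using microsomes, with a stated time of 1 h, tested at 5 uM (a higher number here means that more of the compound is left, a lower number that less of the compound is left), compound 1 `Cc1nc(-c2ccccc2)c(C(=O)N2CCN(c3cccc(C)c3C)CC2)o1` gives 29.8% and sits in the upper part of the three measured numbers. Within the scatter of it stands compound 2 `Cc1ccc(C)c(N2CCN(C(=O)c3oc(C)nc3-c3ccccc3)CC2)c1` with 33.8% left. Compound 3 `COc1cc(OC)cc(N2CCN(C(=O)c3oc(C)nc3-c3ccc(F)cc3)CC2)c1` gives 12.9% left. Within the data shown here, that number lies lower than the one of compound 1, beyond the scatter.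

Compound 4 `Cc1nc(-c2ccccc2)c(C(=O)N2CCN(c3cc(Cl)cc(Cl)c3)CC2)o1` keeps the core of compound 1 and changes one group 3,5-dichlorophenyl in place of 2,3-dimethylphenyl on an amine nitrogen in a ring so that 3,5-dichlorophenyl replaces 2,3-dimethylphenyl on an amine nitrogen in a ring. Among the measured compounds shown here, the only measured step at that place is a number 4 percentage points higher from compound 1 to compound 2 (within the scatter) and it swaps one dimethylphenyl for another. For the measured compounds named here, no measured step brings in chlorine, so the evidence is thin. Compound 3 differs from compound 1 in more than one place and gives no clean comparison.

The estimated step is a number 2.2 percentage points higher from compound 1 to compound 4 (within the scatter) and no shift beyond the scatter is expected. For compound 4 the expected value is 32% within an estimated range from 14% to 52% of compound left.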

Compound 4, percent of the compound remaining: 66.3%
Compound 4: the middle estimate sits 34.3 percentage points below what was measured; the whole stated range lies below it.
By their numbers in this assay, from the lowest: compound 3; then compounds 1 and 2 (each within the scatter of the next); then compound 4.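

In this assay, the aryl group on the amine nitrogen in a ring has far more influence than the swap between two dimethylphenyl groups suggested: 3,5-dichlorophenyl gives a number 36.5 percentage points higher from compound 1 to compound 4 (beyond the scatter) and a number 32.5 percentage points higher from compound 2 to compound 4 (beyond the scatter). Both large steps keep the heavy-atom count of the aryl group, its six-membered aromatic ring of carbon only and its lack of hydrogen-bond donors and acceptors, so these counts do not distinguish the groups. Nothing measured here bears on why the number changes so much.

The compounds shown leave open whether the step follows the two chlorine atoms or their placement on the ring, as both differ from the dimethylphenyl groups. A 3,5-dimethylphenyl or 2,3-dichlorophenyl group at this place would separate the two.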